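Replacing Methyl with Trifluoromethyl in an Antiproliferative Series

The source may report more compounds than this note shows. Statements on the series, on what has been measured and on what is new or still open speak of the compounds shown alone.

In a functional assay on MCF7 cells (Homo sapiens) for antiproliferative activity, with a stated time of 5 days (on this read-out lower numbers stand for stronger inhibition and higher numbers for weaker inhibition), compound 1 (`COc1ccc(-c2[nH]c3ccccc3c2C=O)cc1`) gives 180 nM, compound 2 (`CCCCc1ccc2[nH]c(-c3ccc(OC)cc3)c(C=C(C#N)C#N)c2c1`) gives 13 nM, and compound 3 (`CCCCc1ccc2[nH]c(-c3ccc(C)cc3)c(C=C(C#N)C#N)c2c1`) gives 100 nM. Compound 3 thus lies within the scatter of compound 1 and well beyond the scatter of compound 2 on the weaker side. Compound 4 (`CCCCc1ccc2[nH]c(-c3ccc(C(F)(F)F)cc3)c(C=C(C#N)C#N)c2c1`) differs from compound 3 by trifluoromethyl in place of methyl on an aromatic carbon. For the measured compounds named here, the one measured step at this place is a 7.7-fold higher number from compound 2 to compound 3 (0.89 log units; beyond the scatter), with methyl in place of methoxy on an aromatic carbon, and it is modest but beyond the scatter. Going by the values given here, it shows that the read-out can respond to a change here, but no measured compound carries trifluoromethyl, so it gives only weak guidance on direction. A modest move toward a higher number is therefore expected, smaller than that single step. The expected change is a 1.8-fold higher number from compound 3 to compound 4 (0.26 log units; within the scatter). For compound 4 the estimated value is 180 nM, with an expected range from 50 nM to 600 nM.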

Compound 4, half-maximal inhibitory concentration: 150 nM
Beside the measured number, compound 4's estimate is 1.2-fold (0.08 log units) above it, within the range that was stated.
By their numbers in this assay, from the lowest: compound 2; then compounds 3, 4 and 1 (each within the scatter of the next).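

In this assay, trifluoromethyl in place of methyl gives a 1.5-fold higher number from compound 3 to compound 4 (0.18 log units; within the scatter), so on this aromatic carbon, para to a large group, the read-out does not separate these two groups. Methoxy is what stands apart here: a 12-fold higher number from compound 2 to compound 4 (1.06 log units; beyond the scatter), a large step that, together with a 7.7-fold higher number from compound 2 to compound 3 (0.89 log units; beyond the scatter), leaves compound 2 alone on the lower side of the three compounds that differ at this place. No evidence on the cause of this result is available.

On these data alone, whether the lower number of compound 2 is particular to methoxy, or would also appear with an ethoxy, a hydroxyl or an amine at this place, stays open. So does whether the gap between methoxy and the other two groups would persist with a different chain in place of the butyl chain.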